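The source may report more compounds than this note shows. Statements on the series, on what has been measured and on what is new or still open speak of the compounds shown alone.

Measured so far:
compound 1 `COc1ccc(-c2cc(/C=C/C(=O)c3ccc(N)cc3)[nH]n2)cc1`, 2030 nM in a functional assay on A498 cells (Homo sapiens) for inhibition, read by sulforhodamine B assay, with a stated time of 48 h; a higher number here means a weaker inhibitor of growth, a lower number a stronger inhibitor of growth
compound 2 `COc1ccc(C(=O)/C=C/c2cc(-c3cc(OC)c(OC)c(OC)c3)n[nH]2)cc1OC`, 1480 nM
compound 3 `COc1ccc(-c2cc(/C=C/C(=O)c3ccc(N)cc3)[nH]n2)cc1OC`, 2370 nM

The three values lie within the scatter of one another, so no order among them is claimed. The difference between the core of compound 1 and the core of compound 2 is not broken down here.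

Compound 1 and compound 3 differ in one place:
methoxy in place of hydrogen on an aromatic carbon
This step gave a 1.2-fold higher number from compound 1 to compound 3 (0.07 log units; within the scatter).

The unmeasured compound 4 `COc1cc(C(=O)/C=C/c2cc(-c3cc(OC)c(OC)c(OC)c3)n[nH]2)cc(OC)c1OC` is made from compound 2 by the same kind of change:
methoxy in place of hydrogen on an aromatic carbon
The two places are not identical: around the place in compound 4 the entering group is also meta to a methoxy group, which is not so in compound 3.

For compound 4 the step from compound 2 is expected to be about a 1.1-fold higher number from compound 2 to compound 4 (0.06 log units; within the scatter), resting on the small step seen from compound 1 to compound 3, a 1.2-fold higher number from compound 1 to compound 3 (0.07 log units; within the scatter). Compound 4 is therefore estimated at 1700 nM, between 800 nM and 3600 nM.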

Compound 4, concentration for 50% growth inhibition: 1610 nM
For compound 4 the middle estimate is 1.1-fold (0.02 log units) above the measured one; low and high end bracket the measured number.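

In this assay, methoxy in place of hydrogen on an aromatic carbon gives a 1.1-fold higher number from compound 2 to compound 4 (0.04 log units; within the scatter). Set beside the earlier step, the change shows no difference between the two cores: the same change on two cores in this assay, a 1.2-fold higher number (0.07 log units; within the scatter) from compound 1 to compound 3 and a 1.1-fold higher number (0.04 log units; within the scatter) from compound 2 to compound 4, 1.1-fold (0.03 log units) apart, within the scatter of two such steps. Both steps are small and lie within the scatter, so this shows that the change leaves the number about where it was on these two cores, but it does not show a real effect of the methoxy group on either core or predict the outcome on any other core.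

Open, on these data alone, is whether a different group at such a place, such as an amine, a carboxylic acid or a longer alkoxy chain, would give a step beyond the scatter. Also open, as far as these compounds go, is whether methoxy behaves the same way on an aromatic ring with no methoxy group already on it.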